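A few compounds are considered here, and "the series" means these few. Any claim that something is new, unique, unknown or untested is made for them only; others in the source may bear on it.

Measured compounds:
compound 1, `Cc1cc(Oc2ccc(/C=N/NC(=S)Nc3ccc(F)cc3)cc2)ccc1Cl`, 6.07
compound 2, `Cc1cc(Oc2ccc(/C=N/NC(=S)Nc3ccc(Br)cc3)cc2)ccc1Cl`, 7.89

Among the compounds with values here, in a physicochemical assay for lipophilicity, in phosphate buffer, measured as octanol-water partition, with a stated time of 24 h (on this read-out lower numbers stand for lower lipophilicity and higher numbers for higher lipophilicity), compound 1 stands at the lower of the two numbers; the reading rises a number 1.82 log units higher from compound 1 to compound 2 (beyond the scatter), and that is the only measured step. The unmeasured compound 3, `Fc1ccc(NC(=S)N/N=C/c2ccc(Oc3ccc(Cl)cc3)cc2)cc1`, differs from compound 1 in one place: hydrogen in place of methyl on an aromatic carbon. The methyl leaves, so that the 4-chloro-3-methylphenoxy group of compound 1 becomes 4-chlorophenoxy in compound 3. Within the data shown here, the single measured step exchanges one halogen for another and does not bear directly on the loss of a methyl, so nothing measured here calibrates this change. The expectation rests on the change itself: the departure of one carbon is expected to lower the partition coefficient by a modest step, a number 0.47 log units lower from compound 1 to compound 3 (beyond the scatter). Compound 3 is therefore estimated at 5.6, within a range from 5.1 to 6.1.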

Compound 3, partition coefficient: 5.78
Compound 3: middle estimate off by 0.18 log units, on the low side; the measured number falls inside the stated range.
By their numbers in this assay, from the lowest: compounds 3 and 1 (each within the scatter of the next); then compound 2.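

In this assay, hydrogen in place of methyl on this aromatic carbon, ortho to a chloro group, gives a step that stays inside the usual scatter (a number 0.29 log units lower from compound 1 to compound 3 (within the scatter)), so compound 1 and compound 3 cannot be told apart on this read-out. Within the data shown here, this is the first reading at this place, since the earlier step, bromo in place of fluoro (a number 1.82 log units higher from compound 1 to compound 2 (beyond the scatter)), concerned a different place and remains the only step here beyond the scatter. No measurement on hand offers an explanation for this reading.

The compounds shown leave open how an ethyl chain, a methoxy group or an amine would read at this place. They also leave open whether hydrogen in place of methyl would read the same with bromo in place of fluoro.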